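Acylating the Aromatic Nitrogen of Compound 1

A few compounds are considered here, and "the series" means these few. Any claim that something is new, unique, unknown or untested is made for them only; others in the source may bear on it.

Compound 1 `COc1cc2ccnc(-c3ccc(N)cc3)c2cc1OC` is the starting point. Among the measured compounds shown here, in an assay on heart for inhibition of phosphodiesterase 1 (Bos taurus), read by cAMP accumulation (a higher number here means a weaker inhibitor, a lower number a stronger inhibitor), compound 1 gives 7400 nM, the highest of the two numbers measured so far, though its nearest neighbour lies within the scatter. Compound 2 `COC(=O)/C=C\C(=O)Nc1ccc(-c2nccc3cc(OC)c(OC)cc23)cc1` carries a (2-(methoxycarbonyl)ethenyl)carbonyl group on the same nitrogen; in this assay compound 2 gives 5300 nM, a step of a 1.4-fold lower number from compound 1 to compound 2 (0.14 log units; within the scatter), which is within the scatter. Compound 3 `COC(=O)/C=C/C(=O)Nc1ccc(-c2nccc3cc(OC)c(OC)cc23)cc1` differs from compound 1 by (2-(methoxycarbonyl)ethenyl)carbonyl in place of hydrogen on a nitrogen on an aromatic ring. For the measured compounds named here, the only step that bears on it is the one from compound 1 to compound 2, which adds the same group and differs from compound 3 only in the geometry of its double bond; that step was small and within the scatter. The step of a 1.3-fold lower number from compound 1 to compound 3 (0.13 log units; within the scatter) is therefore expected to stay within the scatter. Compound 3 is expected to give 5500 nM, in the range 2500 nM to 12000 nM.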

Compound 3, half-maximal inhibitory concentration: 14000 nM
Compound 3: the middle estimate sits 2.5-fold (0.41 log units) below what was measured; measured number above the stated range.
By their numbers in this assay, from the lowest: compounds 2, 1 and 3 (each within the scatter of the next, the first and the last beyond it).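

In this assay, attaching (2-(methoxycarbonyl)ethenyl)carbonyl to the nitrogen on an aromatic ring gives a 1.9-fold higher number from compound 1 to compound 3 (0.28 log units; within the scatter), so in the E form, as in the Z form of compound 2, the addition of the group stays within the scatter of compound 1. Among the compounds shown here, the new information lies between the two forms: a 2.6-fold higher number from compound 2 to compound 3 (0.42 log units; beyond the scatter), the only step in this set beyond the scatter, though a modest one. This gap can be assigned to the geometry of the double bond alone, because nothing else separates the two compounds: the fact that compounds 2 and 3 differ only in the configuration as drawn

The compounds shown leave open whether this difference between the two geometries persists when the methoxycarbonyl end is replaced by a carboxylic acid or a primary amide. They also leave open what a saturated chain in place of the ethenyl link would give at this nitrogen.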